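Methyl for Bromo on the Aryl Ring of Compound 2

The source may hold more compounds than are shown below. What is called first, only, known or untested is meant among the compounds shown, and "the series" means these compounds.

In a functional assay on A549 cells (Homo sapiens) for cytotoxicity, read by XTT assay, with a stated time of 24 h (a higher number here means a weaker inhibitor, a lower number a stronger inhibitor), compound 1 `Cn1nnnc1SCC(=O)N/N=C/c1ccccc1Cl` gives 6320000 nM, and compound 2 `Cn1nnnc1SCC(=O)N/N=C/c1ccccc1Br` gives 2000000 nM, the lowest of the two numbers. The step of a 3.2-fold lower number from compound 1 to compound 2 (0.50 log units; beyond the scatter) is the only one measured. Compound 3 `Cc1ccccc1/C=N/NC(=O)CSc1nnnn1C` differs from compound 2 by methyl in place of bromo on an aromatic carbon. Going by the values given here, no measured step exchanges a halogen for a methyl here, so the step of a 3.2-fold lower number from compound 1 to compound 2 (0.50 log units; beyond the scatter) bears on it only loosely, and compound 3 is expected to land near compound 2, with a step of a 1.8-fold higher number from compound 2 to compound 3 (0.24 log units; within the scatter) in this assay. For compound 3 the estimate is 3500000 nM, with a range from 1200000 nM to 10000000 nM.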

Compound 3, half-maximal inhibitory concentration: > 10000000 nM
Compound 3: no number, only a limit; the forecaster's own chance of this, stated with the estimate: 20%; at least 2.8-fold (0.45 log units) between middle value and limit.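

Compound 3 reaches only a limit in this assay: the limit of > 10000000 nM in this assay, at which 1 of the 3 values shown sits. The earlier compounds shown here compared only chloro with bromo, whereas here a non-halogen group at this place, ortho to a large group, gives an at least 5.0-fold higher number from compound 2 to compound 3 (0.69 log units; beyond the scatter), so methyl does not match bromo. Against chloro the result is less firm, with an at least 1.5-fold higher number from compound 1 to compound 3 (0.19 log units; that floor lies within the scatter), so no order of methyl and chloro can be claimed.

Going by these compounds, how far the true value of compound 3 lies past its limit remains open. So does whether an amine or a methoxy group at this place would give a lower number than bromo.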